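Fluoro for trifluoromethyl at the assay limit

A few compounds are considered here, and "the series" means these few. Any claim that something is new, unique, unknown or untested is made for them only; others in the source may bear on it.

Measured in a functional assay on HT-29 cells (Homo sapiens); on this read-out higher numbers stand for weaker inhibition of growth and lower numbers for stronger inhibition of growth:
compound 1 `O=S(=O)(/C=C/c1ccc(F)cc1F)Cc1ccc(Nc2ncnc3ccccc23)cc1`: > 100000 nM (a limit)
compound 2 `O=S(=O)(/C=C/c1ccc(C(F)(F)F)cc1F)Cc1ccc(Nc2ncnc3ccccc23)cc1`: 100000 nM
compound 3 `O=S(=O)(/C=C/c1ccc(C(F)(F)F)cc1F)Cc1ccc(Nc2ncnc3cc(Cl)ccc23)cc1`: > 100000 nM (a limit)

Compound 3 has no number of its own, only the limit > 100000 nM. It belongs with the rest of the series, which sits largely at the limit of > 100000 nM in this assay, at which 2 of the 3 values shown sit. The next compound is compound 4 `O=S(=O)(/C=C/c1ccc(F)cc1F)Cc1ccc(Nc2ncnc3cc(Cl)ccc23)cc1`, and the change is fluoro in place of trifluoromethyl on an aromatic carbon, para to a large group.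

The closest measured evidence is the reverse swap on the core without chloro, a number no higher from compound 1 to compound 2 (the limit leaves the size open). Adding chloro gave a number no lower from compound 2 to compound 3 (the limit leaves the size open). Neither step has a readable size, so neither points to a gain in growth inhibition of any known magnitude. No step beyond the scatter is therefore expected, and another limit is the likeliest report. The expected change is a number no higher from compound 3 to compound 4 (the limit leaves the size open). In this assay compound 4 is estimated at 100000 nM, with an expected range of 50000 nM to 200000 nM.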

Compound 4, concentration for 50% growth inhibition: > 100000 nM
Compound 4 ended at the assay's limit; the forecaster's own chance of this, stated with the estimate: 85%; the middle value sits exactly at the limit.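

Compound 1, compound 3 and compound 4 all stand at limits, and the steps from compound 3 and from compound 1 to compound 4 cannot be read. The compounds shown leave open how large any change in growth inhibition from these swaps is, with the series resting largely at one limit: the limit of > 100000 nM in this assay, at which 3 of the 4 values shown sit.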